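Stereocentre inversion at a limit in liver microsomes

The compounds below may be only part of what the source reports. "The series", "measured", "known", "first", "only" and "open" are said of these compounds alone.

Measured compounds:
compound 1 `CC(=O)NCCN1CC[C@H](C)Nc2cc(ccc2C(N)=O)-n2c(c(C)c3c2CC(C)(C)CC3=O)CC1=O` — > 0.5 h
compound 2 `Cc1c2c(n3c1CCN(C(=O)[C@@H](C)N)CC[C@H](C)Nc1cc-3ccc1C(N)=O)CC(C)(C)CC2=O` — > 0.5 h

In an in vitro ADME assay on microsomes from liver (Rattus norvegicus) for metabolic stability (on this read-out lower numbers stand for a shorter-lived compound and higher numbers for a longer-lived compound), compound 1 gives > 0.5 h, which is a limit of the assay rather than a number. In this assay compound 2 likewise gives > 0.5 h, again a limit of the assay. Compound 2 thus stands at the limit of > 0.5 h in this assay, at which 2 of the 2 values shown sit, with no number of its own. Compound 3 `Cc1c2c(n3c1CCN(C(=O)[C@H](C)N)CC[C@H](C)Nc1cc-3ccc1C(N)=O)CC(C)(C)CC2=O` differs from compound 2 as follows: the two compounds have the same atoms and bonds and differ only in configuration as drawn: 1 of 2 stereo elements differ; a stereocentre at a saturated chain carbon is drawn R in compound 2 and S in compound 3. The step from compound 2 to compound 3 in this assay is expected to be none beyond the scatter a step that the limit leaves unreadable from compound 2 to compound 3. Compound 3 is estimated at 1 h, between 0.5 h and 3 h, most likely reported again only as a limit.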

Compound 3, half-life: > 0.5 h
Compound 3: no number, only a limit; the forecaster's own chance of this, stated with the estimate: 75%; the middle value does not contradict the limit.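

The step between compound 2 and compound 3 in this assay cannot be read, as both results are limits of the assay. The compounds shown leave open whether inverting this stereocentre changes the half-life at all.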